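Notes on the step from compound 2 to compound 4

The source may hold more compounds than are shown below. What is called first, only, known or untested is meant among the compounds shown, and "the series" means these compounds.

The series is read in a functional assay on BGC-823 cells (Homo sapiens) for cytotoxicity, read by MTT assay; on this read-out higher numbers stand for weaker inhibition and lower numbers for stronger inhibition. Compound 1 `COc1cc(/C=C/C(=O)c2sc(Nc3ccccc3C)nc2C)cc(OC)c1OC` gives 5400 nM, and compound 3 `COc1cccc(/C=C/C(=O)c2sc(Nc3ccc(Cl)c(Cl)c3)nc2C)c1` gives 8350 nM in this assay. Compound 2 `Cc1ccc(Nc2nc(C)c(C(=O)/C=C/c3ccc(Cl)cc3)s2)cc1` returns no number in this assay but only a limit, > 25000 nM. This is the limit of > 25000 nM in this assay, at which 1 of the 3 values shown sits, so compound 2 stands at the edge of what the read-out reports, while compounds 1 and 3 sit well inside the measured range.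

Compound 4 `Cc1nc(Nc2cccc(Cl)c2)sc1C(=O)/C=C/c1ccc(Cl)cc1` has not yet been measured. It differs from compound 2 by 3-chlorophenyl in place of 4-methylphenyl on a nitrogen on an aromatic ring. Among the compounds with values here, no pair of measured compounds shows this single change, so the size of the step is open. Within the data shown here, the only other compound with chlorine on the aryl group at that nitrogen, compound 3, returned a number rather than a limit, though it also differs from compound 2 elsewhere and cannot be read as a clean comparison.

The expectation is that compound 4 moves inward from the limit of compound 2 by a modest step, an at least 1.6-fold lower number from compound 2 to compound 4 (0.22 log units; that floor lies within the scatter), with a real chance that it too returns only a limit. The estimate for compound 4 is 15000 nM, with a range from 5000 nM to 40000 nM.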

Compound 4, half-maximal inhibitory concentration: > 25000 nM
Compound 4: no number, only a limit; the forecaster's own chance of this, stated with the estimate: 40%; at least 1.6-fold (0.22 log units) between middle value and limit.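

In this assay compound 4 returns only a limit, > 25000 nM. Compound 2 stands at a limit as well, so no step can be read between compound 2 and compound 4: the limit of > 25000 nM in this assay, at which 2 of the 4 values shown sit.

The compounds shown leave open in which direction, and how far, 3-chlorophenyl in place of 4-methylphenyl on a nitrogen on an aromatic ring moves the value.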